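From propoxy to propylamino on compound 3

The source may report more compounds than this note shows. Statements on the series, on what has been measured and on what is new or still open speak of the compounds shown alone.

In a functional assay on cells (Platelet, Homo sapiens) for inhibition (on this read-out higher numbers stand for weaker inhibition and lower numbers for stronger inhibition), compound 3 `CCCOC(=O)c1ccc(-c2nn(Cc3ccccc3)c3ccccc23)cc1` gives > 10000 nM as a limit and not a number. Compound 1 `CCOC(=O)c1ccc(-c2nn(Cc3ccccc3Cl)c3ccccc23)cc1` gives > 10000 nM as a limit too. Compound 2 `CCOC(=O)c1ccc(-c2nn(Cc3ccccc3F)c3ccccc23)cc1` gives > 10000 nM as a limit as well. The series thus offers only the limit of > 10000 nM in this assay, at which 3 of the 3 values shown sit, and no measured number. Within the data shown here, compound 4 `CCCNC(=O)c1ccc(-c2nn(Cc3ccccc3)c3ccccc23)cc1` carries propylamino in place of propoxy on a carbonyl carbon as its sole difference from compound 3. Among the measured compounds shown here, the one measured step that the two limits leave unreadable from compound 1 to compound 2 is a different change and has no readable size, so it gives no guide here. The estimated step in this assay is a step that the limit leaves unreadable from compound 3 to compound 4 with no direction supported by the data. Compound 4 is expected near 15000 nM with an estimated range of 4000 nM to 60000 nM and may well report only a limit.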

Compound 4, half-maximal inhibitory concentration: > 10000 nM
Compound 4: a limit, no number (the forecaster's own chance of this, stated with the estimate: 80%); the middle value does not contradict the limit.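

In this assay compound 3 and compound 4 both stand only as limits, and the step between them cannot be read. The compounds shown leave open whether in this assay any change on the shared core yields a measured number rather than a limit.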